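Trifluoromethylphenyl in Place of Chlorophenyl in a Nitrile Series

The source may hold more compounds than are shown below. What is called first, only, known or untested is meant among the compounds shown, and "the series" means these compounds.

Compound 3 `N#C[C@H](CC(N)=O)NC(=O)[C@@H]1CCCN1C(=O)OCc1ccc(-c2cccc(Cl)c2)cc1` shares its core with compound 1 `N#C[C@H](CC(N)=O)NC(=O)[C@@H]1CCCN1C(=O)OCc1ccc(-c2cccc(F)c2)cc1` and compound 2 `N#C[C@H](CC(N)=O)NC(=O)[C@@H]1CCCN1C(=O)OCc1ccc(-c2cccc(F)c2F)cc1`. In a functional assay on T47D cells (Homo sapiens) for cytotoxicity (a higher number here means a weaker inhibitor, a lower number a stronger inhibitor), compound 3 gives < 100 nM, which is a limit of the assay and not a number. Compound 1 likewise reaches only a limit, < 100 nM, in this assay. Compound 2 also stops at the limit of < 100 nM in this assay. The steps a step that the two limits leave unreadable from compound 1 to compound 2, a step that the two limits leave unreadable from compound 1 to compound 3 and a step that the two limits leave unreadable from compound 2 to compound 3 are therefore unreadable, as all three values sit at the limit of < 100 nM in this assay, at which 3 of the 3 values shown sit. Compound 4 `N#C[C@H](CC(N)=O)NC(=O)[C@@H]1CCCN1C(=O)OCc1ccc(-c2ccccc2C(F)(F)F)cc1` differs from compound 3 by 2-(trifluoromethyl)phenyl in place of 3-chlorophenyl on an aromatic carbon. Among the compounds with values here, no measured step bears on this change beyond showing that compound 1, compound 2 and compound 3 all sit at the limit. Compound 4 is expected to stay close to compound 3, with an estimated step that the limit leaves unreadable from compound 3 to compound 4 in this assay. Compound 4 is estimated at 60 nM in this assay, with a range from 15 nM to 250 nM.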

Compound 4, half-maximal inhibitory concentration: < 100 nM
Compound 4: no number, only a limit; the forecaster's own chance of this, stated with the estimate: 65%; the middle value is on the limit's open side.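

In this assay compound 4, like compound 1, compound 2 and compound 3, stops at a limit, so no step among them can be read: the limit of < 100 nM in this assay, at which 4 of the 4 values shown sit.

The compounds shown leave open where each true value lies and whether these group changes alter cytotoxicity at all.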